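Swapping the aryl on the piperazine in an oxazole amide series

The compounds below may be only part of what the source reports. "The series", "measured", "known", "first", "only" and "open" are said of these compounds alone.

Compound 1 `CCc1nc(-c2cccc(F)c2)c(C(=O)N2CCN(c3cccc(Cl)c3)CC2)o1`: 317 nM
Compound 2 `CC(=O)c1ccc(N2CCN(C(=O)c3oc(C)nc3-c3ccccc3)CC2)cc1`: "not active" (no number reported)
Compound 3 `COc1cccc(N2CCN(C(=O)c3oc(C)nc3-c3ccc(F)cc3)CC2)c1`: 112 nM

Compound 2 stands apart from the other two: in a functional assay on HL-60 cells (Homo sapiens) for inhibition, read by MTT assay, with a stated time of 72 h (a higher number here means a weaker inhibitor, a lower number a stronger inhibitor), compound 2 is reported only as "not active" (no number reported), with no number attached, so its place on the scale cannot be fixed. Compound 1 and compound 3, which differ from compound 2 in more than one place, each give a number. Compound 4 `Cc1nc(-c2ccccc2)c(C(=O)N2CCN(c3cccc(Cl)c3)CC2)o1` arises from compound 2 by the change (3-chlorophenyl in place of 4-acetylphenyl on an amine nitrogen in a ring). For the measured compounds named here, compound 1 carries the same 3-chlorophenyl group on its ring nitrogen and gives 317 nM, so a step from compound 2 to compound 4 toward a stronger inhibitor, beyond the usual scatter, is expected, although no measured pair fixes its size. Compound 4 is therefore estimated at 300 nM, within a range from 80 nM to 1500 nM.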

Compound 4, half-maximal inhibitory concentration: 39.2 nM
Compound 4: the middle estimate sits 7.7-fold (0.88 log units) above what was measured; measured number outside the range, below it.
By their numbers in this assay, from the lowest: compound 4; then compound 3; then compound 1.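

No step can be read from compound 4: compound 2 has no number, and compound 1 and compound 3 each differ from it in more than one place. The compounds shown leave open what each single change contributes. Nothing shown explains the result.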